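The source may hold more compounds than are shown below. What is called first, only, known or untested is meant among the compounds shown, and "the series" means these compounds.

In a functional assay on ECa-109 cells for inhibition, with ECa-109 cell line (Homo sapiens) as the target, read by sulforhodamine B assay (on this read-out lower numbers stand for stronger inhibition and higher numbers for weaker inhibition), compound 1 `CCc1ccc(NC2=CC(=O)c3nc4n(c3C2=O)[C@H]2OC[C@@H](O)[C@H]2OC4)cc1` gives 3080 nM. Among the three measured compounds this is the lowest number, yet it is not separated from the others: compound 2 `COc1ccc(NC2=CC(=O)c3c(nc4n3[C@H]3OC[C@@H](O)[C@H]3OC4)C2=O)cc1` gives 3410 nM in this assay, and compound 3 `CCOc1ccccc1NC1=CC(=O)c2c(nc3n2[C@H]2OC[C@@H](O)[C@H]2OC3)C1=O` gives 4320 nM, both within the usual scatter of compound 1. Among the measured compounds shown here, the only single-point step measured so far is a 1.3-fold higher number from compound 2 to compound 3 (0.10 log units; within the scatter), which swaps one group on the amine nitrogen for another without moving the number beyond the scatter.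

Compound 4 `O=C1C=C(Nc2cccc(Cl)c2)C(=O)c2c1nc1n2[C@H]2OC[C@@H](O)[C@H]2OC1` differs from compound 1 by 3-chlorophenyl in place of 4-ethylphenyl on an amine nitrogen. For the measured compounds named here, no measured step exchanges a 4-ethylphenyl for a 3-chlorophenyl, so the closest guide is the step from compound 2 to compound 3, where a change of the group on the same nitrogen stayed within the scatter. The step from compound 1 to compound 4 is therefore expected to be small, a 1.1-fold higher number from compound 1 to compound 4 (0.06 log units; within the scatter), with no clear direction. Compound 4 is estimated to give 3500 nM in this assay, expected to lie between 1500 nM and 8500 nM.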

Compound 4, half-maximal inhibitory concentration: 4690 nM
Compound 4: middle estimate off by 1.3-fold (0.13 log units), on the low side; the range from low to high includes it.
By their numbers in this assay, from the lowest: compounds 1, 2, 3 and 4 (each within the scatter of the next).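

In this assay, the change to 3-chlorophenyl on the amine nitrogen gives a 1.5-fold higher number from compound 1 to compound 4 (0.18 log units; within the scatter), so this step also stays within the scatter. The earlier compounds shown here carried only ethyl, methoxy or ethoxy groups on the phenyl ring, whereas compound 4 shows that a chlorine in their place likewise leaves the number inseparable from those of compound 1, compound 2 and compound 3. No evidence is available that bears on this result.

The compounds shown leave open whether any group at this position can move the number beyond the scatter at all. Whether a carboxylic acid or a dimethylamino group on the phenyl ring, or a longer alkyl chain in place of that ring, would do so remains an open question.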